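Adding an amino group to compound 1

A few compounds are considered here, and "the series" means these few. Any claim that something is new, unique, unknown or untested is made for them only; others in the source may bear on it.

Compound 1 `CCn1cc(-c2nc3ccccc3[nH]2)c(=O)c2cc(F)c(N3CCNCC3)nc21`: > 10000 nM (a limit)
Compound 2 `CCn1cc(-c2nc3ccc([N+](=O)[O-])cc3o2)c(=O)c2cc(F)c(N3CCNC(C)C3)c(F)c21`: 3500 nM
Compound 3 `CCn1cc(-c2nc3ccc([N+](=O)[O-])cc3o2)c(=O)c2cc(F)c(N3CCNCC3)nc21`: > 10000 nM (a limit)

All three compounds were tested in a functional assay on THP-1 cells (Homo sapiens) for cytotoxicity, read by sulforhodamine B assay, with a stated time of 48 h; a lower number here means a stronger inhibitor, a higher number a weaker inhibitor. Compound 1 stands at the limit of > 10000 nM in this assay, at which 2 of the 3 values shown sit. Its reading is a limit and not a number. For the measured compounds named here, compound 2 is the only one with a true number, 3500 nM.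

Compound 4 `CCn1cc(-c2nc3ccc(N)cc3[nH]2)c(=O)c2cc(F)c(N3CCNCC3)nc21` is still unmeasured and changes compound 1 in one place: amino in place of hydrogen on an aromatic carbon. In words, this is amino in place of hydrogen on an aromatic carbon. Going by the values given here, no two measured compounds differ in only one place, so the size of such a change has not been seen directly. The expectation therefore starts from compound 1 and its limit of > 10000 nM. The estimated step that the limit leaves unreadable from compound 1 to compound 4 is expected to be small, with no firm direction. For compound 4 the expected value is 12000 nM, with an estimated range of 4000 nM to 30000 nM.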

Compound 4, half-maximal inhibitory concentration: 8200 nM
The estimate for compound 4 lay 1.5-fold (0.17 log units) above the measured number; low and high end bracket the measured number.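

In this assay, compound 4 gives a true number, 8200 nM, so with an amino group on this aromatic carbon the reading falls inside the range the assay can report. The change itself can be stated only as a floor, an at least 1.2-fold lower number from compound 1 to compound 4 (0.08 log units; that floor lies within the scatter), so a real gain in potency can be neither claimed nor ruled out. The true size of the step stays hidden since compound 1 carries a limit and not a number: the limit of > 10000 nM in this assay, at which 2 of the 4 values shown sit.

The compounds shown leave open whether a hydroxyl or a methoxy group on this same aromatic carbon would give a lower number than the amino group does. They also leave open whether a longer chain on that amino nitrogen would keep the reading within the range of the assay.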